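Furan-3-yl for ethynyl on two nucleoside cores

The source may hold more compounds than are shown below. What is called first, only, known or untested is meant among the compounds shown, and "the series" means these compounds.

The series is followed in a functional assay on CCRF-CEM cells (Homo sapiens), read by MTT assay, with a stated time of 72 h; on this read-out higher numbers stand for weaker inhibition and lower numbers for stronger inhibition. Compound 1 `C#Cc1cn([C@@H]2O[C@H](CO)[C@@H](O)[C@H]2O)c2ncnc(C)c12` gives 5600 nM in this assay. Compound 2 `Cc1ncnc2c1c(-c1ccoc1)cn2[C@@H]1O[C@H](CO)[C@@H](O)[C@H]1O` carries furan-3-yl in place of ethynyl on an aromatic carbon. In this assay compound 2 is reported only as a limit, > 20000 nM. The step of an at least 3.5-fold higher number from compound 1 to compound 2 (0.55 log units; beyond the scatter) corresponds to the counted change (furan-3-yl in place of ethynyl on an aromatic carbon); its size rests on (the limit of > 20000 nM in this assay, at which 1 of the 3 values shown sits), so only its lower bound is known.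

Compound 3 `C#Cc1cn([C@@H]2O[C@H](CO)[C@@H](O)[C@H]2O)c2nc(N)nc(OC)c12` has a different core; the difference between the two cores is not broken down here. In this assay compound 3 is reported only as a limit, > 100000 nM, sitting at the limit of > 100000 nM in this assay, at which 1 of the 3 values shown sits.

Compound 4 `COc1nc(N)nc2c1c(-c1ccoc1)cn2[C@@H]1O[C@H](CO)[C@@H](O)[C@H]1O` has not been measured in this assay. It differs from compound 3 by furan-3-yl in place of ethynyl on an aromatic carbon, and the place of the change reads word for word as it does for compound 1 to compound 2, so this is the same change on the second core. That change weakened compound 1 to compound 2 by an at least 3.5-fold higher number from compound 1 to compound 2 (0.55 log units; beyond the scatter). Compound 3 already stands at a limit, so a value beyond that limit is expected for compound 4, with a step that the limit leaves unreadable from compound 3 to compound 4 as the expected step. The estimate for compound 4 in this assay is 300000 nM, expected to fall between 100000 nM and 3000000 nM, most likely returned again as a limit.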

Compound 4, half-maximal inhibitory concentration: > 20000 nM
Compound 4: no number, only a limit (the forecaster's own chance of this, stated with the estimate: 95%); the middle value lies beyond the limit too.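

In this assay compound 4 is reported only as a limit, > 20000 nM. Compound 3 is also reported only as a limit, > 100000 nM. No step can be read from compound 3 to compound 4, so furan-3-yl in place of ethynyl has no measurable size on this core. The compounds shown leave open whether this change shifts activity on the core of compound 3 as it does on the core of compound 1.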